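Replacing one aromatic substituent in a cytotoxicity series

The source may hold more compounds than are shown below. What is called first, only, known or untested is meant among the compounds shown, and "the series" means these compounds.

In an ADME assay on MT4 cells (Homo sapiens) for cytotoxicity (on this read-out lower numbers stand for higher toxicity in this test and higher numbers for lower toxicity in this test), compound 1 `COC(=O)N[C@H](C(=O)NN(CCC[C@@](O)(Cc1ccccc1)C(=O)N[C@H]1c2ccccc2C[C@H]1O)Cc1ccc(F)cc1)C(C)(C)C` gives > 10000 nM as a limit of the assay. Compound 2 `COC(=O)N[C@H](C(=O)NN(CCC[C@@](O)(Cc1ccccc1)C(=O)N[C@H]1c2ccccc2C[C@H]1O)Cc1ccc(OCc2cnc(Cl)s2)cc1)C(C)(C)C` gives > 10000 nM as a limit too. The evidence so far is the limit of > 10000 nM in this assay, at which 2 of the 2 values shown sit, and nothing more. Compound 3 `COC(=O)N[C@H](C(=O)NN(CCC[C@@](O)(Cc1ccccc1)C(=O)N[C@H]1c2ccccc2C[C@H]1O)Cc1ccc(-c2ccncc2)cc1)C(C)(C)C` differs from compound 2 by pyridin-4-yl in place of (2-chloro-1,3-thiazol-5-yl)methoxy on an aromatic carbon as pyridin-4-yl comes in place of (2-chloro-1,3-thiazol-5-yl)methoxy on an aromatic carbon. Going by the values given here, with a step that the two limits leave unreadable from compound 1 to compound 2 as the only measured step, no step beyond the scatter is expected in this assay and no direction can be given. The expected change is a number no higher from compound 2 to compound 3 (the limit leaves the size open) for this replacement. Compound 3 is estimated at 10000 nM within an expected range from 4000 nM to 25000 nM in this assay.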

Compound 3, half-maximal cytotoxic concentration: > 10000 nM
Compound 3: only a limit was reported; the forecaster's own chance of this, stated with the estimate: 70%; the middle value lies on the limit itself.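

Going by these compounds alone, compound 3 gives > 10000 nM, a limit of the assay, and no step among compound 1, compound 2 and compound 3 can be read. The compounds shown leave open what actual value each would reach in this assay, and whether exchanging the aromatic substituent changes it at all.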